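Cytotoxicity limits across a shared-core amide series

This account rests on a few compounds, and the source may have more. Where it says the series, first, only, none or still open, it means among the compounds named here.

The series shares one core and differs only in the distal aryl group. Compound 1 `CC(C)N(Cc1cccc(OCCCCCC(=O)O)c1)C(=O)c1ccc(-c2cccc(Oc3ccccc3)c2)cc1`, compound 2 `CC(C)N(Cc1cccc(OCCCCCC(=O)O)c1)C(=O)c1ccc(-c2ccsc2)cc1`, compound 3 `CC(C)N(Cc1cccc(OCCCCCC(=O)O)c1)C(=O)c1ccc(-c2cccc(OCc3ccccc3)c2)cc1` and the not yet measured compound 4 `COc1ccc(F)c(-c2ccc(C(=O)N(Cc3cccc(OCCCCCC(=O)O)c3)C(C)C)cc2)c1` belong to it. In an ADME assay on Raji cells (Homo sapiens) for cytotoxicity, read by CellTiter-Glo and resazurin assay, with a stated time of 72 h (on this read-out lower numbers stand for an effect already at smaller amounts and higher numbers for an effect only at larger amounts of compound), compound 1 reaches only a limit of > 18700 nM. In this assay compound 2 likewise gives only a limit, > 26000 nM. Compound 3 also stops at a limit of > 26000 nM in this assay. Going by the values given here, the single step between compounds differing in one place, a step that the two limits leave unreadable from compound 1 to compound 3, is therefore of unreadable size. Among the compounds with values here, compound 2 stands at the limit of > 26000 nM in this assay, at which 2 of the 3 values shown sit, alongside compound 3, while compound 1 sits at the limit of > 18700 nM in this assay, at which 1 of the 3 values shown sits; no measured step has a readable size. The change toward compound 4 is 2-fluoro-5-methoxyphenyl in place of thiophen-3-yl on an aromatic carbon. Within the data shown here, no measured step bears directly on this change; all three values are limits, so no step beyond the scatter is expected, and another limit is the likeliest outcome. Compound 4 is estimated at 30000 nM, expected to lie between 10000 nM and 100000 nM. The step that the limit leaves unreadable from compound 2 to compound 4 that this estimate means is expected to stay within the scatter.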

Compound 4, half-maximal effective concentration: > 26000 nM
Compound 4 gave a limit, no number (the forecaster's own chance of this, stated with the estimate: 85%); the middle value does not contradict the limit.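

Going by these compounds alone, compound 2 and compound 4 both give only limits in this assay, so the step between them cannot be read and no new step follows. The compounds shown leave open whether any distal aryl group on the shared core gives a numerical value in this assay.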